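Swapping a hydroxylated side chain on the thiophene amide

A few compounds are considered here, and "the series" means these few. Any claim that something is new, unique, unknown or untested is made for them only; others in the source may bear on it.

Compounds measured so far:
compound 1 `CC1(C)CNC(=O)c2sc(Nc3ccc(I)cc3Cl)c(C(=O)NCC[C@@H](O)CO)c2C1`: 12100 nM
compound 2 `CCOC(=O)c1c(Nc2ccc(I)cc2F)sc2c1CC(C)(C)CNC2=O`: "not determined" (no result reported)

Compound 1 carries a dihydroxybutyl chain on its amide nitrogen. Among the compounds with values here, in a functional assay on HT-29 cells (Homo sapiens) for antiproliferative activity (on this read-out higher numbers stand for weaker inhibition and lower numbers for stronger inhibition), compound 1 gives 12100 nM, which is the only number available in this set; compound 2, a related ester, has no result in this assay and is recorded as "not determined" (no result reported), so it offers no comparison. Compound 1 therefore stands alone as the single reference point.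

Compound 3 `CC1(C)CNC(=O)c2sc(Nc3ccc(I)cc3Cl)c(C(=O)NOC[C@H](O)CO)c2C1` differs from compound 1 in one place: 2,3-dihydroxypropoxy in place of 3,4-dihydroxybutyl on an amide-type nitrogen. The change keeps the two hydroxyl groups and the same count of heavy atoms, while one carbon of the chain gives way to an oxygen bonded directly to the amide nitrogen. Within the data shown here, no measured pair shows what such a swap does here.

With nothing to anchor a direction, the step of a 1.0-fold lower number from compound 1 to compound 3 (0.00 log units; within the scatter) is expected to stay within the scatter, in no particular direction. Compound 3 is therefore estimated at 12000 nM, with a range from 4000 nM to 40000 nM.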

Compound 3, half-maximal inhibitory concentration: 896 nM
The estimate for compound 3 lay 13-fold (1.13 log units) above the measured number, and the stated range ends above it.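

In this assay, putting 2,3-dihydroxypropoxy in place of 3,4-dihydroxybutyl on the amide-type nitrogen gives a 14-fold lower number from compound 1 to compound 3 (1.13 log units; beyond the scatter), which means stronger inhibition and a step well outside ordinary measurement variation. Within the data shown here, this is the first sign that the side chain at this position matters: the two chains have the same count of heavy atoms and hydrogen-bond donors, yet a swap of carbon for oxygen in the chain is enough to produce a large change in the read-out. Nothing available explains why this edit has such an effect, so the result stands as an observation rather than a mechanism.

This single pair cannot show whether the gain comes from the oxygen attached to the amide nitrogen alone or depends on that oxygen working together with the two hydroxyl groups. A plain propoxy or methoxy group would help separate those two possibilities, while a longer chain, or an amine or carboxylic acid at the end of the chain, would show how much variation this position tolerates.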